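Changing the side group of compound 3

This account rests on a few compounds, and the source may have more. Where it says the series, first, only, none or still open, it means among the compounds named here.

Of the compounds shown here, three sharing one core have been tested in a functional assay on HepG2 cells (Homo sapiens) for inhibition, read by MTT assay, with a stated time of 48 h; a higher number here means a weaker inhibitor, a lower number a stronger inhibitor. Compound 1 `CCOC(=O)C1=C(N/N=C(/C(=O)Br)c2ccc(Br)cc2)Nc2[nH]nc(C)c2C1c1ccc(N(C)C)cc1` gives 65000 nM, compound 2 `CCOC(=O)C1=C(NN=C(C#N)C#N)Nc2[nH]nc(C)c2C1c1ccc(N(C)C)cc1` gives 13700 nM, and compound 3 `CCOC(=O)C1=C(N/C=N/c2ccc(C)cc2)Nc2[nH]nc(C)c2C1c1ccc(N(C)C)cc1` gives 44400 nM. Compound 3 therefore cannot be told apart from compound 1, while compound 2 is the clearly stronger inhibitor of the pair it forms with compound 3.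

Compound 4 `CCOC(=O)C1=C(N/N=C(/C(C)=O)C(=O)OCC)Nc2[nH]nc(C)c2C1c1ccc(N(C)C)cc1` differs from compound 3 on an amine nitrogen: a group of 10 heavy atoms (6 carbon, 1 nitrogen, 3 oxygen; no ring) in place of a group of 9 heavy atoms (8 carbon, 1 nitrogen; one six-membered aromatic ring of carbon only), on an amine nitrogen. All three measured steps involve a change on this same nitrogen. Compound 2 also carries a group with no ring, and the step there is modest: a 3.2-fold higher number from compound 2 to compound 3 (0.51 log units; beyond the scatter). The step of a 4.7-fold lower number from compound 1 to compound 2 (0.68 log units; beyond the scatter) is also modest, and a 1.5-fold lower number from compound 1 to compound 3 (0.17 log units; within the scatter) stays within the scatter. The group in compound 4 matches none of those tested, so these small steps offer only a loose guide. A small move towards stronger inhibition is the most that can be expected.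

The expected step in this assay is a 1.5-fold lower number from compound 3 to compound 4 (0.17 log units; within the scatter), which would not go beyond the scatter. The estimated value for compound 4 is 30000 nM, with an expected range from 11000 nM to 80000 nM.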

Compound 4, half-maximal inhibitory concentration: > 100000 nM
Compound 4 was reported as a limit (the forecaster's own chance of this, stated with the estimate: 10%); middle value at least 3.3-fold (0.52 log units) from the limit.
By their numbers in this assay, from the lowest: compound 2; then compounds 3 and 1 (each within the scatter of the next). At a limit, above all of these: compound 4.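

Compound 4 is reported in this assay only as a limit: the limit of > 100000 nM in this assay, at which 1 of the 4 values shown sits. Even so, this is the first sign that a group with no ring on this amine nitrogen does not by itself bring stronger inhibition: compound 2 also carries a group with no ring, yet the readings are an at least 7.2-fold higher number from compound 2 to compound 4 (0.86 log units; beyond the scatter) and an at least 2.2-fold higher number from compound 3 to compound 4 (0.35 log units; beyond the scatter). The comparison with the bromine-bearing group gives no clear order, as its floor is small: an at least 1.5-fold higher number from compound 1 to compound 4 (0.18 log units; that floor lies within the scatter).

It remains open whether the ketone or the ethyl ester in the group of compound 4 matters more, as no compound shown carries one without the other. As far as these compounds go, it is also open how a carboxylic acid or a simple amine at the end of a similar chain on this nitrogen would read in this assay.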